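Vinyl to ethynyl on the shared core

This account rests on a few compounds, and the source may have more. Where it says the series, first, only, none or still open, it means among the compounds named here.

In a functional assay on KYSE-70 cells for antiproliferative activity against KYSE-70 cell line (Homo sapiens), read by MTT assay, with a stated time of 72 h (on this read-out lower numbers stand for stronger inhibition and higher numbers for weaker inhibition), compound 1 (`CC(C)(C)c1ccc(-c2ccc3c(C(=O)Nc4cccc(F)c4)cc(=O)[nH]c3c2)cc1`) gives > 20000 nM, which is a limit of the assay and not a number. In this assay, among the measured compounds shown here, compound 2 (`C=Cc1ccc2c(C(=O)Nc3cccc(F)c3)cc(=O)[nH]c2c1`) gives 9700 nM, the only actual number so far.

Compound 3 (`C#Cc1ccc2c(C(=O)Nc3cccc(F)c3)cc(=O)[nH]c2c1`) carries ethynyl in place of vinyl on an aromatic carbon.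

For the measured compounds named here, only one measured step bears on this change: an at least 2.0-fold lower number from compound 1 to compound 2 (0.31 log units; beyond the scatter). That step starts from a limit and replaces a much larger group, so it gives little guide to an exchange of two-carbon groups. With compound 2 at 9700 nM as the anchor, no shift beyond the scatter is expected. For compound 3, a result at the limit of the assay remains possible. The expected change is a 1.1-fold lower number from compound 2 to compound 3 (0.03 log units; within the scatter). The estimate for compound 3 is 9000 nM, with an expected range of 3000 nM to 20000 nM.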

Compound 3, half-maximal inhibitory concentration: 9500 nM
Beside the measured number, compound 3's estimate is 1.1-fold (0.02 log units) below it; low and high end bracket the measured number.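

In this assay, ethynyl in place of vinyl on this aromatic carbon gives a 1.0-fold lower number from compound 2 to compound 3 (0.01 log units; within the scatter), so at this position a triple bond outside aromatic rings and a double bond there read alike. Ethynyl in place of 4-(tert-butyl)phenyl gives an at least 2.1-fold lower number from compound 1 to compound 3 (0.32 log units; beyond the scatter), so a second two-carbon group now shows the same direction as vinyl did. Compound 1 gives a limit and not a number, so the true size of that step stays unknown: the limit of > 20000 nM in this assay, at which 1 of the 3 values shown sits.

The compounds shown leave open whether any group on this carbon moves the number well away from these two values, for example an amine, a carboxylic acid or a longer chain such as propyl. Also open, going by these compounds, is how a plain ethyl group or a hydrogen would read here as a reference for the two-carbon pair.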